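A nitrophenyl group replaces an amide arm on compound 1

The source may report more compounds than this note shows. Statements on the series, on what has been measured and on what is new or still open speak of the compounds shown alone.

Compound 1 `CCOC(=O)C1=Cc2ccccc2OC1(OCc1cn(CC(=O)Nc2ccccc2F)nn1)C(F)(F)F` carries a ((2-fluorophenyl)carbamoyl)methyl group on an aromatic nitrogen of its five-membered aromatic ring with three nitrogens. Among the measured compounds shown here, in a functional assay on DU-145 cells (Homo sapiens) for inhibition, read by MTT assay, with a stated time of 24 h (on this read-out lower numbers stand for stronger inhibition and higher numbers for weaker inhibition), compound 1 gives 33900 nM, which is the only number recorded for the series. Compound 2 `CCOC(=O)C1=Cc2ccccc2OC1(OCc1cc(-c2ccc([N+](=O)[O-])cc2)no1)C(F)(F)F` reaches only the assay limit of > 150000 nM in this assay, so no number is known for it. Compound 3 `CCOC(=O)C1=Cc2ccccc2OC1(OCc1cn(-c2ccc([N+](=O)[O-])cc2)nn1)C(F)(F)F` has not yet been measured in this assay. It differs from compound 1 by 4-nitrophenyl in place of ((2-fluorophenyl)carbamoyl)methyl on an aromatic nitrogen. No step between two measured compounds is available to calibrate this change, so the expected size must rest on the two results shown: compound 2, the other bearer of 4-nitrophenyl, sits at the limit of > 150000 nM in this assay, at which 1 of the 2 values shown sits. The step of a 2.2-fold higher number from compound 1 to compound 3 (0.34 log units; beyond the scatter) is therefore expected to weaken inhibition beyond the usual scatter. Compound 3 is estimated to give 75000 nM in this assay, within a range from 30000 nM to 150000 nM, with a real chance that only a limit is reported.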

Compound 3, half-maximal inhibitory concentration: > 150000 nM
Compound 3 ended at the assay's limit; the forecaster's own chance of this, stated with the estimate: 35%; middle value at least 2.0-fold (0.30 log units) away from the limit.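

In this assay this aromatic nitrogen now has a step that can be read, and replacing ((2-fluorophenyl)carbamoyl)methyl with 4-nitrophenyl gives an at least 4.4-fold higher number from compound 1 to compound 3 (0.64 log units; beyond the scatter) and so weakens inhibition beyond the usual scatter. Compound 3 gives > 150000 nM in this assay, which is a limit and not a number, so the step marks only the smallest possible size of the change. Among the compounds shown, compound 1 alone keeps a measurable value, and the group on this nitrogen is thus shown to decide whether a number can be read at all, while the limit now recurs across the series: the limit of > 150000 nM in this assay, at which 2 of the 3 values shown sit.

The change removes the amide arm and the 2-fluorophenyl ring together and brings in the nitro group at the same time, so the compounds shown cannot say which of these parts accounts for the loss. On these data alone, it also remains open whether a plain phenyl or a 4-aminophenyl on this nitrogen, or a longer chain between the amide and the ring nitrogen, would keep or improve the inhibition seen with compound 1.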